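Swapping the anilino ring: chlorine out, fluorine in

A few compounds are considered here, and "the series" means these few. Any claim that something is new, unique, unknown or untested is made for them only; others in the source may bear on it.

Compound 1 `FC(F)(F)c1ccc(CSc2nc(Nc3ccccc3C(F)(F)F)c3ccccc3n2)cc1` gives > 50000 nM, which is a limit of the assay and not a number.
Compound 2 `Cc1ccccc1Nc1nc(SCc2ccc(C(F)(F)F)cc2)nc2ccccc12` gives 27500 nM.
Compound 3 `FC(F)(F)c1ccc(CSc2nc(Nc3cccc(Cl)c3)c3ccccc3n2)cc1` gives 19900 nM.

All three numbers come from a functional assay on HGC-27 cells (Homo sapiens) for cytotoxicity, read by MTT assay, with a stated time of 72 h; a lower number here means a stronger inhibitor, a higher number a weaker inhibitor. Among the compounds with a number, compound 3 stands lowest, and the nearest is compound 2, which sits within the scatter of it; the value of compound 1 is only a limit, as the limit of > 50000 nM in this assay, at which 1 of the 3 values shown sits, shows. Going by the values given here, the steps so far are small: an at least 1.8-fold lower number from compound 1 to compound 2 (0.25 log units; that floor lies within the scatter), an at least 2.5-fold lower number from compound 1 to compound 3 (0.40 log units; beyond the scatter), and a 1.4-fold lower number from compound 2 to compound 3 (0.14 log units; within the scatter). Among the compounds with values here, only the step from compound 1 to compound 3 reaches beyond the scatter, and it starts from a limit, so its true size is unknown.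

Compound 4 `Fc1ccc(Nc2nc(SCc3ccc(C(F)(F)F)cc3)nc3ccccc23)cc1` differs from compound 3 by a single exchange: 4-fluorophenyl in place of 3-chlorophenyl on a nitrogen on an aromatic ring. The two earlier exchanges on this same nitrogen, from compound 1 to compound 3 and from compound 2 to compound 3, moved the number little, so the expectation for this exchange is likewise a step of about a 1.3-fold higher number from compound 3 to compound 4 (0.10 log units; within the scatter), with no clear direction beyond the scatter. Compound 4 is therefore estimated at 25000 nM in this assay, within a range from 8000 nM to 70000 nM.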

Compound 4, half-maximal inhibitory concentration: 19500 nM
For compound 4 the middle estimate is 1.3-fold (0.11 log units) above the measured one, within the range that was stated.
By their numbers in this assay, from the lowest: compounds 4, 3 and 2 (each within the scatter of the next). At a limit, above all of these: compound 1.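

In this assay the 4-fluorophenyl group cannot be told apart from the 3-chlorophenyl group on this nitrogen, as a 1.0-fold lower number from compound 3 to compound 4 (0.01 log units; within the scatter) shows, and it cannot be told apart from the 2-methylphenyl group either, as a 1.4-fold lower number from compound 2 to compound 4 (0.15 log units; within the scatter) shows. This adds a third group to the set and a new kind of exchange: fluorine on the ring instead of chlorine or methyl, at a different ring position, and the number still holds within the scatter, so compounds 2, 3 and 4 form one level group, with compound 1 as the only one that stands apart. The one step here that reaches beyond the scatter is an at least 2.5-fold lower number from compound 1 to compound 4 (0.40 log units; beyond the scatter) and its true size stays unknown because compound 1 is held at a limit and not a number: the limit of > 50000 nM in this assay, at which 1 of the 4 values shown sits.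

Going by these compounds, all four compounds carry a substituted phenyl ring on this nitrogen, so it remains open whether an amine or a carboxylic acid on that ring, or a longer chain in its place, would shift the number beyond the scatter. On these data alone, the shared core and the sulfur side also stay the same throughout, so what a change there would do remains open too.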